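The compounds below may be only part of what the source reports. "The series", "measured", "known", "first", "only" and "open" are said of these compounds alone.

Measured so far in an assay on membranes from liver for displacement of a labelled ligand from Sigma non-opioid intracellular receptor 1 (Rattus norvegicus), read by scintillation counting; on this read-out lower numbers stand for stronger inhibition and higher numbers for weaker inhibition:
compound 1 `Cc1ccc(CN(C)CCCn2c(=O)oc3ccccc32)cc1` gives 871 nM
compound 2 `COc1ccccc1CN(C)CCCCn1c(=O)oc2ccccc21` gives 594 nM
compound 3 `COc1ccc(CN(C)C(C)CCn2c(=O)oc3ccccc32)cc1` gives 21 nM

Among these three values compound 2 stands second highest. Its nearest neighbour is compound 1, whose number lies within the usual scatter of that of compound 2, so the two cannot be told apart. Its furthest is compound 3, whose number is far lower, a gap well beyond the scatter. No two of the measured compounds differ in only one place, so no single structural step can be read off from them.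

Compound 4 `CN(CCCCn1c(=O)oc2ccccc21)Cc1cccc(Cl)c1` is not yet measured. It differs from compound 2 in one place: 3-chlorophenyl in place of 2-methoxyphenyl on a saturated chain carbon bound to an amine nitrogen. Among the measured compounds shown here, with no measured single step to lean on, the expectation rests on the spread already seen, which reaches from the highest number down to compound 3 at 21 nM. A step toward a lower number is expected, of a size around the edge of the scatter: a 2.4-fold lower number from compound 2 to compound 4 (0.38 log units; beyond the scatter). Compound 4 is therefore expected to give about 250 nM in this assay, with a range from 60 nM to 1000 nM.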

Compound 4, inhibition constant: 302 nM
For compound 4 the middle estimate is 1.2-fold (0.08 log units) below the measured one; the range from low to high includes it.
By their numbers in this assay, from the lowest: compound 3; then compounds 4, 2 and 1 (each within the scatter of the next, the first and the last beyond it).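

Among the compounds shown here, compound 2 and compound 4 form the first pair here that differs in only one place, so a single structural change can finally be read. In this assay, putting 3-chlorophenyl in place of 2-methoxyphenyl on a saturated chain carbon bound to an amine nitrogen gives a 2.0-fold lower number from compound 2 to compound 4 (0.29 log units; within the scatter) and so leaves the two compounds indistinguishable, even though the hydrogen-bond acceptor counted in the leaving group is absent from the entering one. Nothing measured independently offers an explanation for this result.

Since the chlorine and the methoxy group also carry different numbers in their names, the compounds shown leave open whether 3-methoxyphenyl or 2-chlorophenyl would behave the same way. Compound 3 also stays unconnected to the others by any one-place step, so nothing here ties its value to a single structural feature.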